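The source may report more compounds than this note shows. Statements on the series, on what has been measured and on what is new or still open speak of the compounds shown alone.

Compound 1 `CN(C)CCCCCSC1=Nc2ccccc2C(CC(=O)NCc2ccccc2)N1c1ccc(-c2ccc(F)cc2)cc1` gives 66.7% in an assay on cells for inhibition of Voltage-dependent T-type calcium channel subunit alpha-1I (Homo sapiens), read by patch clamp, tested at 10 uM; a higher number here means more inhibition at the concentration tested (going by the name of the read-out), a lower number less inhibition.
Compound 2 `O=C(CC1c2ccccc2N=C(SCCCCCN2CCCC2)N1c1ccccc1)NCc1ccc(F)cc1` gives 22.1% in this assay.
Compound 3 `CN(C)CCCCCSC1=Nc2ccccc2C(CC(=O)NCc2ccc(F)cc2)N1c1ccc(-c2ccc(F)cc2)cc1` gives 92% in this assay.

Compound 1 stands second highest of these three numbers, below compound 3 and well above compound 2. Compound 4 `CN(C)CCCCCSC1=Nc2ccccc2C(CC(=O)NCc2ccccc2)N1c1ccc(-c2ccccc2)cc1` differs from compound 1 in one place: hydrogen in place of fluoro on an aromatic carbon. Within the data shown here, the only single-place step measured is a number 25.3 percentage points higher from compound 1 to compound 3 (beyond the scatter), which added fluoro at a different aromatic carbon of the same core and raised inhibition by a modest amount. Taking fluoro away at another aromatic carbon is expected to act in the opposite direction, if at all, so a modest decrease or a change within the scatter is expected in this assay. Compound 4 is therefore estimated at 55%, within 35% to 75%, a step of a number 11.7 percentage points lower from compound 1 to compound 4 (beyond the scatter).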

Compound 4, a percentage reported as inhibition, at one concentration (the size of the read-out at that concentration, not a potency): 85.6%
For compound 4 the middle estimate is 30.6 percentage points below the measured one; measured number outside the range, above it.
By their numbers in this assay, from the lowest: compound 2; then compound 1; then compounds 4 and 3 (each within the scatter of the next).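

Taking fluoro away from this position gives a number 18.9 percentage points higher from compound 1 to compound 4 (beyond the scatter) in this assay, so the 4-fluorophenyl group is not needed for inhibition at the concentration tested. The fluoro change at the other aromatic carbon, a number 25.3 percentage points higher from compound 1 to compound 3 (beyond the scatter), goes the other way as a change of group, since there adding fluoro raises the number while here removing it does. Nothing available explains this difference between the two positions.

The compounds shown leave open whether chloro, methoxy or a methyl group at this position would read like hydrogen or like fluoro. They also leave open how the same change behaves with a pyrrolidine in place of the dimethylamine.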